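The source may hold more compounds than are shown below. What is called first, only, known or untested is meant among the compounds shown, and "the series" means these compounds.

Working notes on the series. Compound 3 `COc1cc(/C=C/C(=O)OCCCCO[N+](=O)[O-])ccc1OCCCCO[N+](=O)[O-]` has been run in a functional assay on LOX IMVI cells (Homo sapiens) for cytotoxicity, read by resazurin assay, with a stated time of 72 h; a lower number here means a stronger inhibitor, a higher number a weaker inhibitor. In this assay compound 3 gives only a limit, > 50000 nM. Compound 1 `O=C(/C=C/c1ccc(OCCCCO[N+](=O)[O-])c(O)c1)OCCCCO[N+](=O)[O-]` is its counterpart with hydrogen in place of methyl on an oxygen on an aromatic ring. In this assay compound 1 likewise gives only a limit, > 50000 nM. The measured step that the two limits leave unreadable from compound 3 to compound 1 therefore has no readable size, both values sitting at the limit of > 50000 nM in this assay, at which 3 of the 3 values shown sit. Compound 2 `COc1cc(/C=C/C(=O)OCCCO[N+](=O)[O-])ccc1OCCCO[N+](=O)[O-]` carries the shorter chains; the difference between the core of compound 2 and the core of compound 3 is not broken down here. In this assay compound 2 gives only a limit, > 50000 nM. Compound 4 `O=C(/C=C/c1ccc(OCCCO[N+](=O)[O-])c(O)c1)OCCCO[N+](=O)[O-]` has not yet been measured; it differs from compound 2 by hydrogen in place of methyl on an oxygen on an aromatic ring, which is the same change as from compound 3 to compound 1, made at the same place. With the earlier step unreadable and all three values at the limit, the step from compound 2 to compound 4 is expected to be a step that the limit leaves unreadable from compound 2 to compound 4, resting only on the unreadable step that the two limits leave unreadable from compound 3 to compound 1. Compound 4 is accordingly estimated at 80000 nM in this assay, with a range from 30000 nM to 300000 nM, and most likely reported once more only as a limit.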

Compound 4, half-maximal inhibitory concentration: 6940 nM
Compound 4: middle estimate off by 12-fold (1.06 log units), on the high side, outside the stated range (below it).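

On the shorter chains, methoxy to hydroxy gives an at least 7.2-fold lower number from compound 2 to compound 4 (0.85 log units; beyond the scatter) in this assay, and this size is only a bound on the true step, since one end of it is a limit. The same change from compound 3 to compound 1 cannot be read, as both of its ends are limits and not numbers: the limit of > 50000 nM in this assay, at which 3 of the 4 values shown sit. The change is therefore shown to lower the number on one core only; a similar lowering on the longer chains is neither shown nor excluded, so carrying the change from one core to the other remains untested.

The compounds shown leave open whether the lower number needs a free hydroxy at that place, or whether an ethoxy or an amine there would behave in the same way. They also leave open how the step runs on chains longer than those of compound 3, and whether replacing a nitrate ester end with a carboxylic acid would keep the value of compound 4.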